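The compounds below may be only part of what the source reports. "The series", "measured", "known", "first", "only" and "open" are said of these compounds alone.

Compound 1 `O=C(/C=C/c1ccc(OCCCCCO[N+](=O)[O-])c(O)c1)OCCCCCO[N+](=O)[O-]`: in a functional assay on M4E cells (Homo sapiens) for cytotoxicity, read by resazurin assay, with a stated time of 72 h (a higher number here means a weaker inhibitor, a lower number a stronger inhibitor), compound 1 gives > 50000 nM, which is a limit of the assay rather than a number.
Compound 2 `O=C(/C=C/c1ccc(OCCCCCCO[N+](=O)[O-])c(O)c1)OCCCCCCO[N+](=O)[O-]`: in this assay compound 2 gives > 50000 nM, again a limit.
Compound 3 `COc1cc(/C=C/C(=O)OCCCCCO[N+](=O)[O-])ccc1OCCCCCO[N+](=O)[O-]`: in this assay compound 3 gives > 50000 nM, also a limit.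

Compound 3 differs from compound 1 by methyl in place of hydrogen on an oxygen on an aromatic ring. The step that the two limits leave unreadable from compound 1 to compound 3 cannot be read, given (the limit of > 50000 nM in this assay, at which 3 of the 3 values shown sit). Compound 4 `COc1cc(/C=C/C(=O)OCCCCCCO[N+](=O)[O-])ccc1OCCCCCCO[N+](=O)[O-]`, not yet measured, carries the same change relative to compound 2: methyl in place of hydrogen on an oxygen on an aromatic ring. The difference between the cores of compound 1 and compound 2 is not broken down here. With the limit of > 50000 nM in this assay, at which 3 of the 3 values shown sit, there is no readable step to build on, so the expectation for compound 4 rests only on the fact that all three measured values are limits. The step from compound 2 to compound 4 is expected to be a step that the limit leaves unreadable from compound 2 to compound 4. Compound 4 is therefore estimated at 80000 nM, with a range from 40000 nM to 200000 nM, most likely reported as a limit again.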

Compound 4, half-maximal inhibitory concentration: > 50000 nM
Compound 4: only a limit was reported; the forecaster's own chance of this, stated with the estimate: 85%; the middle value is on the limit's open side.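

No step can be read from compound 2 to compound 4, since both values are limits: the limit of > 50000 nM in this assay, at which 4 of the 4 values shown sit. The compounds shown leave open what actual number any of them would give in this assay, and whether hydroxy to methoxy changes it.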